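Compound 3 to compound 4: a step at the limit

A few compounds are considered here, and "the series" means these few. Any claim that something is new, unique, unknown or untested is made for them only; others in the source may bear on it.

In an ADME assay on cells (Lymphocyte, Homo sapiens) for cytotoxicity, read by MTT assay, with a stated time of 48 h (on this read-out lower numbers stand for stronger inhibition and higher numbers for weaker inhibition), compound 1 `COC(=O)/C(=C\c1ccc(O)cc1)Sc1ccnc2cc(Cl)ccc12`, with hydrogen on the oxygen on the aromatic ring, gives 33700 nM. Compound 2 `COC(=O)/C(=C\c1ccc(OC(=O)c2ccccc2)cc1)Sc1ccnc2cc(Cl)ccc12`, with benzoyl on that oxygen, gives > 100000 nM, which is a limit of the assay. Compound 3 `COC(=O)/C(=C\c1ccc(OC(=O)c2c(OC)cccc2OC)cc1)Sc1ccnc2cc(Cl)ccc12`, with (2,6-dimethoxyphenyl)carbonyl on that oxygen, gives > 100000 nM, also a limit. Among the compounds with values here, compound 3 therefore has no number of its own, and the series so far ends at the limit of > 100000 nM in this assay, at which 2 of the 3 values shown sit.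

Compound 4 `COC(=O)/C(=C\c1ccc(OC(=O)c2cc(OC)c(OC)c(OC)c2)cc1)Sc1ccnc2cc(Cl)ccc12` changes only the group on the carbonyl: 3,4,5-trimethoxyphenyl in place of 2,6-dimethoxyphenyl on a carbonyl carbon.

Two measured steps point the same way: an at least 2.9-fold higher number from compound 1 to compound 2 (0.47 log units; beyond the scatter), and an at least 2.9-fold higher number from compound 1 to compound 3 (0.47 log units; beyond the scatter). Both give only a minimum size. Within the data shown here, the one step that changes the group on the carbonyl is a step that the two limits leave unreadable from compound 2 to compound 3, so it offers no size to carry over. Compound 4 keeps an aromatic group on that carbonyl, as compound 3 does, and the nearest guide is an at least 2.9-fold higher number from compound 1 to compound 3 (0.47 log units; beyond the scatter). No readable step towards stronger inhibition is expected in this assay. The expected change is a step that the limit leaves unreadable from compound 3 to compound 4, most likely with another reading at the limit. For compound 4 the estimated value is 130000 nM, with an expected range from 50000 nM to 300000 nM.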

Compound 4, half-maximal inhibitory concentration: 35200 nM
Compound 4: the middle estimate sits 3.7-fold (0.57 log units) above what was measured; measured number outside the range, below it.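

On the carbonyl carbon of this ester, the aromatic group turns out to matter in this assay, which compounds 2 and 3 could not show: 3,4,5-trimethoxyphenyl in place of 2,6-dimethoxyphenyl gives an at least 2.8-fold lower number from compound 3 to compound 4 (0.45 log units; beyond the scatter), and 3,4,5-trimethoxyphenyl in place of phenyl gives an at least 2.8-fold lower number from compound 2 to compound 4 (0.45 log units; beyond the scatter). Capping the oxygen with an aromatic carbonyl group therefore does not by itself bring a reading to the limit. Compound 1 gives 33700 nM and compound 4 gives 35200 nM, two values that sit close together and support no claim of order. Both new steps give only a minimum size, and the step between compound 2 and compound 3 cannot be read: the limit of > 100000 nM in this assay, at which 2 of the 4 values shown sit.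

Open is which of the three methoxy groups of compound 4 accounts for the change, since the compounds shown do not separate their contributions. Also open, on these data alone, is how the reading would respond to an acetyl group on the same oxygen, or to an amine or a carboxylic acid on the aromatic ring of the acyl group.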